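Adding a methoxy group to compound 2

The source may hold more compounds than are shown below. What is called first, only, known or untested is meant among the compounds shown, and "the series" means these compounds.

Measured in a physicochemical assay for solubility, in phosphate buffer, measured as kinetic solubility; a higher number here means a more soluble compound, a lower number a less soluble compound:
- compound 1 `CCCN(CC1CCOCC1)c1c(CC)nn2c(-c3c(OC)cc(COC)cc3OC)cccc12` gives 3100 nM
- compound 2 `CCc1nn2c(-c3c(OC)cc(C)cc3OC)cccc2c1N(CC1CCOCC1)CC1CC1` gives 1600 nM

In this assay, compound 2 at 1600 nM lies within the usual scatter of compound 1 at 3100 nM, so these two numbers cannot be told apart. Compound 3 `CCc1nn2c(-c3c(OC)cc(COC)cc3OC)cccc2c1N(CC1CCOCC1)CC1CC1` has not been measured. It differs from compound 2 by a single change, methoxy in place of hydrogen on a saturated chain carbon bound to an aromatic carbon, which turns methyl into methoxymethyl. For the measured compounds named here, no measured pair shows this change alone, so its size is unknown. Compound 1 also carries methoxymethyl and gives 3100 nM, which points to a small rise at best, perhaps none beyond the scatter. The expected change is a 1.8-fold higher number from compound 2 to compound 3 (0.24 log units; within the scatter). For compound 3 the estimated value is 2800 nM, with an expected range from 1100 nM to 7000 nM.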

Compound 3, solubility: 4800 nM
Compound 3: the middle estimate sits 1.7-fold (0.23 log units) below what was measured; measured number inside the range.
By their numbers in this assay, from the lowest: compounds 2, 1 and 3 (each within the scatter of the next, the first and the last beyond it).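

In this assay, for the compounds shown here, methoxy in place of hydrogen on a saturated chain carbon bound to an aromatic carbon, which turns methyl into methoxymethyl, now has a measured size (a 3.0-fold higher number from compound 2 to compound 3 (0.48 log units; beyond the scatter)), a modest step beyond the scatter that no earlier pair could show. The other new pair differs elsewhere, with cyclopropyl in place of ethyl on a saturated chain carbon bound to a nitrogen on an aromatic ring, and its step stays within the scatter (a 1.5-fold higher number from compound 1 to compound 3 (0.19 log units; within the scatter)), so that swap shows no readable change. Nothing given here accounts for the size of either step.

From the compounds shown here alone, the methoxymethyl result rests on a single pair, so it remains open whether it holds on other cores. Going by these compounds, it is also open how a longer chain such as ethoxymethyl, or an amine such as aminomethyl, would read at this place.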